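This account rests on a few compounds, and the source may have more. Where it says the series, first, only, none or still open, it means among the compounds named here.

Compound 1 `S=C(SCc1cn(Cc2ccc(Cl)c(Cl)c2)nn1)N1CCNCC1`: "not determined" (no result reported) in a functional assay on PC-3 cells (Homo sapiens) for inhibition, read by MTT assay, with a stated time of 72 h; on this read-out lower numbers stand for stronger inhibition and higher numbers for weaker inhibition
Compound 2 `O=C(OCc1ccccc1)N1CCN(C(=S)SCc2cn(Cc3ccc(Cl)c(Cl)c3)nn2)CC1`: > 128000 nM
Compound 3 `COc1ccc(Cn2cc(CSC(=S)N3CCN(C(=O)OC(C)(C)C)CC3)nn2)cc1`: > 128000 nM

Three compounds have been examined, and a fourth, compound 4 `CC(C)(C)OC(=O)N1CCN(C(=S)SCc2cn(Cc3ccc(Cl)c(Cl)c3)nn2)CC1`, is yet to be measured. For compound 1 no number was reported. The value of compound 2 is a limit of the assay and not a number. The value of compound 3 is likewise a limit of the assay and not a number. Compound 3 therefore stands at the limit of > 128000 nM in this assay, at which 2 of the 3 values shown sit, with no measured number of its own.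

Compound 4 differs from compound 3 by 3,4-dichlorophenyl in place of 4-methoxyphenyl on a saturated chain carbon bound to an aromatic nitrogen. Going by the values given here, no step between measured compounds is available to gauge the size of this change. Compound 2 also carries the 3,4-dichlorobenzyl group and gave only a limit. Compound 4 is accordingly expected to stay at the limit as well, and the step of a number no higher from compound 3 to compound 4 (the limit leaves the size open) is expected to be none beyond the scatter. Compound 4 is estimated at 128000 nM, with a range from 40000 nM to 400000 nM.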

Compound 4, half-maximal inhibitory concentration: > 128000 nM
Compound 4 ended at the assay's limit; the forecaster's own chance of this, stated with the estimate: 80%; the middle value lies on the limit itself.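

No step can be read among compound 2, compound 3 and compound 4, as each gave only a limit and not a number: the limit of > 128000 nM in this assay, at which 3 of the 4 values shown sit. The compounds shown leave open whether 3,4-dichlorobenzyl in place of 4-methoxybenzyl, or tert-butyl in place of benzyl, changes inhibition at all.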